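Swapping Chloro for Nitro in Three Ovarian-Cell Growth Inhibitors

The compounds below may be only part of what the source reports. "The series", "measured", "known", "first", "only" and "open" are said of these compounds alone.

Compound 1 `CC1=CC[C@H](C(C)(C)NC(=S)N/N=C/c2ccccc2Cl)CC1` gives 83600 nM in a functional assay on OVCAR-3 cells (Homo sapiens) for inhibition, read by sulforhodamine B assay, with a stated time of 48 h; on this read-out higher numbers stand for weaker inhibition of growth and lower numbers for stronger inhibition of growth.
Compound 2 `CC1=CC[C@H](C(C)(C)NC(=S)N/N=C/c2cccc(Cl)c2)CC1` gives 80500 nM in this assay.
Compound 3 `CC1=CC[C@H](C(C)(C)NC(=S)N/N=C/c2ccccc2[N+](=O)[O-])CC1` gives 25800 nM in this assay.

The three measured compounds share one core and differ only in the substituted aryl group on the carbon with a double bond to nitrogen. Compound 1 and compound 2 are built from the same atoms joined differently: 3-chlorophenyl in place of 2-chlorophenyl on a carbon with a double bond to nitrogen. This rearrangement gives a 1.0-fold lower number from compound 1 to compound 2 (0.02 log units; within the scatter), so the two chlorophenyl isomers cannot be told apart in this assay.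

The second change is nitro in place of chloro on an aromatic carbon, which gives a 3.2-fold lower number from compound 1 to compound 3 (0.51 log units; beyond the scatter).

Compound 4 `CC1=CC[C@H](C(C)(C)NC(=S)N/N=C/c2cccc([N+](=O)[O-])c2)CC1` is not yet measured. It differs from compound 2 by nitro in place of chloro on an aromatic carbon. This is the same kind of change as that from compound 1 to compound 3, but the place is not the same: in compound 3 the entering group sits ortho to a large group, in compound 4 it sits meta to a large group. Within the data shown here, the author expects a step of a 2.9-fold lower number from compound 2 to compound 4 (0.46 log units; beyond the scatter) from compound 2 to compound 4, resting on the single precedent a 3.2-fold lower number from compound 1 to compound 3 (0.51 log units; beyond the scatter) and on the near-identical starting points of the two chlorophenyl compounds. Compound 1 gives 83600 nM and compound 2 gives 80500 nM in this assay. Among the measured compounds shown here, for compound 4 the author estimates 28000 nM in this assay, within a range from 12000 nM to 75000 nM, the width reflecting that only one such step is known and at a different place.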

Compound 4, concentration for total growth inhibition: > 100000 nM
Compound 4: only a limit was reported; the forecaster's own chance of this, stated with the estimate: 10%; middle value at least 3.5-fold (0.55 log units) from the limit.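

Nitro in place of chloro did not carry over from one core to the other in this assay, since the lower number seen on the core of compound 1 did not appear on the core of compound 2: the same change on two cores in this assay, a 3.2-fold lower number (0.51 log units; beyond the scatter) from compound 1 to compound 3 and an at least 1.2-fold higher number (0.09 log units; that floor lies within the scatter) from compound 2 to compound 4, at least 4.0-fold (0.60 log units) apart, beyond the scatter of two such steps. Compound 4 gives > 100000 nM in this assay, which is a limit of the assay and not a number: the limit of > 100000 nM in this assay, at which 1 of the 4 values shown sits. Going by these compounds, the step therefore reads only as an at least 1.2-fold higher number from compound 2 to compound 4 (0.09 log units; that floor lies within the scatter), so its true size stays unknown, and with a single pair on each side the comparison shows that this change cannot be assumed to transfer, but not whether the place of the entering group alone decides the outcome.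

The compounds shown leave open how other groups would behave at the aromatic carbon that holds the chloro of compound 2, such as an amine, a nitrile or a carboxylic acid. They also leave open whether a longer chain between the aromatic ring and the carbon with a double bond to nitrogen would change the outcome of swapping chloro for nitro.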